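A few compounds are considered here, and "the series" means these few. Any claim that something is new, unique, unknown or untested is made for them only; others in the source may bear on it.

Three compounds share one core bearing a 4-hydroxyphenyl group. In an assay on isolated protein for inhibition of DNA topoisomerase 1 (Homo sapiens), with a stated time of 30 min, tested at 20 uM (a lower number here means a weaker effect, a higher number a stronger effect of the compound at the concentration tested), compound 1 `Oc1ccc(-c2cc(-c3ccncc3)nc(-c3ccc(Cl)cc3)c2)cc1` gives "not determined" (no result reported) and compound 2 `Oc1ccc(-c2cc(-c3ccc(Cl)cc3)nc(-c3ccccn3)c2)cc1` gives "not determined" (no result reported), so neither has a result there. Among the compounds with values here, compound 3 `Oc1ccc(-c2cc(-c3cccc(Cl)c3)nc(-c3cccs3)c2)cc1` is the only one with a number: in this assay compound 3 gives 0%, which shows no effect at the concentration tested, and it stands alone, with no measured neighbour to compare against. Compound 4 `Oc1ccc(-c2cc(-c3ccc(Cl)cc3)nc(-c3cccs3)c2)cc1` is built from the same atoms joined differently: 4-chlorophenyl in place of 3-chlorophenyl on an aromatic carbon. Within the data shown here, no measured pair shows what this change does here, so no step size is known from the data. The step of a number 3 percentage points higher from compound 3 to compound 4 (within the scatter) that his expectation means is estimated to lie within the scatter, in no clear direction. In this assay compound 4 is estimated at 3%, between 0% and 15%.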

Compound 4, a percentage reported as inhibition, at one concentration (the size of the read-out at that concentration, not a potency): 0%
Beside the measured number, compound 4's estimate is 3 percentage points above it; low and high end bracket the measured number.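

Within the data shown here, with the chlorine shifted, 4-chlorophenyl in place of 3-chlorophenyl on the aromatic carbon next to the ring nitrogen gives the first readable step in this assay, with no change at the digits printed from compound 3 to compound 4 (within the scatter). At this position, then, the two chlorophenyl groups cannot be told apart, and neither of them gives a measurable effect at the concentration tested. Nothing at hand explains this result.

On these data alone, it remains open whether an amine or a carboxylic acid in place of the chlorine would give any inhibition on the shared core. As far as these compounds go, the part played by the thiophen-2-yl group also remains open.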